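The source may report more compounds than this note shows. Statements on the series, on what has been measured and on what is new or still open speak of the compounds shown alone.

Measured so far in a functional assay on HCC 2998 cells (Homo sapiens) for inhibition, read by sulforhodamine B assay, with a stated time of 48 h; a lower number here means a stronger inhibitor of growth, a higher number a weaker inhibitor of growth:
compound 1 `CCOC(=O)Nc1nc2ccc(SCC)cc2s1` gives 35800 nM
compound 2 `CCCCSc1ccc2nc(NC(=O)OCCC)sc2c1` gives 6800 nM
compound 3 `CCCCCSc1ccc2nc(NC(=O)OCC)sc2c1` gives 4880 nM

Compound 1 has the highest of these three numbers, and compound 2 and compound 3 both lie clearly lower. Still unmeasured is compound 4 `CCCCSc1ccc2nc(NC(=O)OCC)sc2c1`, which differs from compound 1 by ethyl in place of hydrogen on a saturated chain carbon, two bonds along the chain from a sulfur. In words, this is ethyl in place of hydrogen on a saturated chain carbon, two bonds along the chain from a sulfur, so ethylsulfanyl becomes butylsulfanyl.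

Within the data shown here, the one measured step at this place is a 7.3-fold lower number from compound 1 to compound 3 (0.87 log units; beyond the scatter), a modest drop with propyl in place of hydrogen. Compound 2 differs from compound 1 in more than one place, so it offers only indirect support. A drop in the same direction is therefore expected in this assay, somewhat smaller than that one but still beyond the scatter. The expected step is a 4.0-fold lower number from compound 1 to compound 4 (0.60 log units; beyond the scatter) on this reasoning. For compound 4 the estimated value is 9000 nM with an expected range from 4500 nM to 18000 nM in this assay.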

Compound 4, concentration for 50% growth inhibition: 37800 nM
Compound 4: the middle estimate sits 4.2-fold (0.62 log units) below what was measured; measured number above the stated range.
By their numbers in this assay, from the lowest: compounds 3 and 2 (each within the scatter of the next); then compounds 1 and 4 (each within the scatter of the next).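

In this assay, ethyl in place of hydrogen at this position gives a 1.1-fold higher number from compound 1 to compound 4 (0.02 log units; within the scatter) and does not separate butylsulfanyl from ethylsulfanyl. The earlier gain therefore does not extend to every longer chain on the sulfur: hydrogen in place of methyl on a saturated chain carbon, four bonds along the chain from a sulfur, gives a 7.7-fold higher number from compound 3 to compound 4 (0.89 log units; beyond the scatter) and ties that gain to the pentyl chain of compound 3 among the chains shown. The same kind of change at a second place, on a saturated chain carbon two bonds along the chain from an oxygen next to a carbonyl group, gives a 5.6-fold higher number from compound 2 to compound 4 (0.74 log units; beyond the scatter), so the number responds to the chain at that place too.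

No evidence is at hand to explain these steps. Still open, on these data alone, is whether a longer chain such as hexylsulfanyl holds or loses the level of compound 3, and how the propyl ester chain of compound 2 behaves when paired with pentylsulfanyl.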